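A few compounds are considered here, and "the series" means these few. Any claim that something is new, unique, unknown or untested is made for them only; others in the source may bear on it.

Of the compounds shown here, two sharing one core have been measured. Compound 1 `Cn1ccc2c(Oc3ccc(NC(=O)c4nn(-c5ccc(Cl)c(C(F)(F)F)c5)ccc4=O)cc3)ccnc21` carries a trifluoromethyl on its outer chlorophenyl ring; in a functional assay on PC-3 cells (Homo sapiens) for cytotoxicity, read by MTT assay, with a stated time of 72 h (a lower number here means a stronger inhibitor, a higher number a weaker inhibitor), compound 1 gives 10300 nM. Compound 2 `Cn1ccc2c(Oc3ccc(NC(=O)c4nn(-c5ccc(Cl)c(F)c5)ccc4=O)cc3F)ccnc21` carries a fluoro in that position instead and an added fluorine on the central ring; in this assay compound 2 gives 17900 nM. These two numbers lie within the usual scatter of each other, so neither compound can be called the stronger inhibitor on this evidence.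

Compound 3 `Cn1ccc2c(Oc3ccc(NC(=O)c4nn(-c5ccc(Cl)c(C(F)(F)F)c5)ccc4=O)cc3F)ccnc21` has not yet been measured. It differs from compound 2 in one place: trifluoromethyl in place of fluoro on an aromatic carbon. Compound 3 therefore pairs the outer ring of compound 1 with the fluorinated central ring of compound 2.

Within the data shown here, no measured pair shows this exact exchange. Since compound 1 gives 10300 nM and compound 2 gives 17900 nM, the step from compound 2 to compound 3 is expected to be small, at most a modest move toward a lower number, and possibly nothing beyond the scatter, so the expected step is a 1.5-fold lower number from compound 2 to compound 3 (0.17 log units; within the scatter). Compound 3 is estimated in this assay at 12000 nM, with a range from 5000 nM to 30000 nM.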

Compound 3, half-maximal inhibitory concentration: 20900 nM
Compound 3: middle estimate off by 1.7-fold (0.24 log units), on the low side; the range from low to high includes it.
By their numbers in this assay, from the lowest: compounds 1, 2 and 3 (each within the scatter of the next, the first and the last beyond it).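

In this assay the exchange of fluoro for trifluoromethyl, ortho to the chloro group on the outer ring, gives a 1.2-fold higher number from compound 2 to compound 3 (0.07 log units; within the scatter) and so brings no readable change, even though the entering group has four heavy atoms where the leaving one has a single atom. The same compound also completes a second pair, in which fluoro in place of hydrogen on the central ring gives a 2.0-fold higher number from compound 1 to compound 3 (0.31 log units; beyond the scatter) as a modest step, and this is the only step shown that lies beyond the scatter. Nothing in the data shown explains either step.

Among these compounds, whether this outer position would respond to a different kind of group, such as an amine, a methoxy group or a carboxylic acid, stays open, since fluoro and trifluoromethyl are the only two groups compared there. Going by these compounds, it is also open whether the step from hydrogen to fluoro on the central ring would look the same with a 4-chloro-3-fluorophenyl outer ring, as only the 4-chloro-3-(trifluoromethyl)phenyl pair can be read here.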